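The source may hold more compounds than are shown below. What is called first, only, known or untested is meant among the compounds shown, and "the series" means these compounds.

Measured in an ADME assay on MT4 cells (Homo sapiens) for cytotoxicity, read by XTT assay, with a stated time of 5 days; on this read-out lower numbers stand for higher toxicity in this test and higher numbers for lower toxicity in this test:
Compound 1 `COC(=O)N[C@H](C(=O)NN(CC[C@@](O)(Cc1ccccc1)C(=O)N[C@H]1c2ccccc2C[C@H]1O)Cc1ccc(-c2ccncc2)cc1)C(C)(C)C`: > 10000 nM
Compound 2 `COC(=O)N[C@H](C(=O)NN(CC[C@@](O)(Cc1ccccc1)C(=O)N[C@H]1c2ccccc2C[C@H]1O)Cc1ccc(-c2cc(F)cc(F)c2)cc1)C(C)(C)C`: > 10000 nM

Compound 2 stands at > 10000 nM, which is a limit of the assay and not a number. It has no numerical position, and the same is true of compound 1, as the limit of > 10000 nM in this assay, at which 2 of the 2 values shown sit, shows.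

Compound 3 `COC(=O)N[C@H](C(=O)NN(CC[C@@](O)(Cc1ccccc1)C(=O)N[C@H]1c2ccccc2C[C@H]1O)Cc1ccc(-c2ccc(NC(C)=O)cc2)cc1)C(C)(C)C` keeps the core of compound 2 but carries 4-acetamidophenyl in place of 3,5-difluorophenyl on an aromatic carbon, para to a large group: 4-acetamidophenyl in place of 3,5-difluorophenyl on an aromatic carbon.

Going by the values given here, only one measured step bears on this change: a step that the two limits leave unreadable from compound 1 to compound 2. It swapped the group at the same place, but its size cannot be read. In this assay, no step beyond the usual scatter is therefore expected, in either direction. The expected step is a step that the limit leaves unreadable from compound 2 to compound 3. For compound 3 the estimated value is 15000 nM, with an expected range from 8000 nM to 40000 nM.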

Compound 3, half-maximal cytotoxic concentration: > 10000 nM
Compound 3: a limit, no number (the forecaster's own chance of this, stated with the estimate: 80%); the middle value does not contradict the limit.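

No new step can be read among compound 1, compound 2 and compound 3 in this assay, because each value is a limit of the assay and not a number: the limit of > 10000 nM in this assay, at which 3 of the 3 values shown sit.

The compounds shown leave open whether the three differ at all in toxicity, and whether any group at this place would bring a readable number.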